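Benzyl substituent swap on the diaminoquinoxaline-free shared core

The compounds below may be only part of what the source reports. "The series", "measured", "known", "first", "only" and "open" are said of these compounds alone.

Measured in a functional assay on M14 cells (Homo sapiens) for inhibition, read by sulforhodamine B assay, with a stated time of 48 h; a higher number here means a weaker inhibitor of growth, a lower number a stronger inhibitor of growth:
compound 1 `Nc1cc(N)c2nc(-c3ccccc3)c(NCc3ccc(Cl)c(Cl)c3)nc2c1` gives 34700 nM
compound 2 `Nc1cc(N)c2nc(-c3ccccc3)c(Sc3ccc(F)cc3)nc2c1` gives 30900 nM
compound 3 `Nc1cc(N)c2nc(-c3ccccc3)c(Oc3ccc(F)cc3)nc2c1` gives 44700 nM

Compound 1 stands second highest of the three numbers, with compound 2 nearest and compound 3 furthest; both gaps lie within the scatter, so the three values cannot be placed in any order of growth inhibition. Going by the values given here, the only step between compounds differing in one place is a 1.4-fold higher number from compound 2 to compound 3 (0.16 log units; within the scatter), which concerns the group on an aromatic carbon and is itself within the scatter.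

Compound 4 `COc1ccc(CNc2nc3cc(N)cc(N)c3nc2-c2ccccc2)cc1` differs from compound 1 by 4-methoxyphenyl in place of 3,4-dichlorophenyl on a saturated chain carbon bound to a nitrogen on an aromatic ring. Among the compounds with values here, no measured step touches this place: compound 1 is the only compound carrying a benzyl group on the ring nitrogen, and the step between compound 2 and compound 3 sits elsewhere on the core. The data therefore give no direction for the swap. Within the data shown here, with all three measured values clustered within the scatter of one another and the one measured step also within it, the expectation for a 1.1-fold higher number from compound 1 to compound 4 (0.04 log units; within the scatter) is no step beyond the scatter. Compound 4 is estimated at 38000 nM, with a range of 15000 nM to 95000 nM.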

Compound 4, concentration for total growth inhibition: 32400 nM
For compound 4 the middle estimate is 1.2-fold (0.07 log units) above the measured one, within the range that was stated.
By their numbers in this assay, from the lowest: compounds 2, 4, 1 and 3 (each within the scatter of the next).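

In this assay, the place on a saturated chain carbon bound to a nitrogen on an aromatic ring now has its first measured step: 4-methoxyphenyl in place of 3,4-dichlorophenyl gives a 1.1-fold lower number from compound 1 to compound 4 (0.03 log units; within the scatter). The exchange is a real change of group at equal size by count, with 8 heavy atoms on each side, both chlorines leaving and 1 hydrogen-bond acceptor entering, yet the read-out does not separate the two benzyl groups, so this pair gives no direction for the place. No measurement at hand bears on what lies behind this result.

Still open, as far as these compounds go, is whether any group at this place can produce a step beyond the scatter, for example an amine or a carboxylic acid on the aromatic ring of the benzyl group, or a longer chain in place of 3,4-dichlorobenzyl. Also open, from the compounds shown here alone, is whether a change at this place would read the same with something other than the phenyl group on the shared core, since every compound here carries that phenyl group.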